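Moving the Chlorine on a Three-Ring Topoisomerase 1 Series

This account rests on a few compounds, and the source may have more. Where it says the series, first, only, none or still open, it means among the compounds named here.

Compound 1, `Oc1cccc(-c2cc(-c3cccnc3)nc(-c3cccc(Cl)c3)c2)c1`, gives 27.6% in an assay on isolated protein for inhibition of DNA topoisomerase 1 (Homo sapiens), with a stated time of 30 min, tested at 100 uM; on this read-out lower numbers stand for a weaker effect and higher numbers for a stronger effect at the one concentration tested. Compound 2, `Oc1ccc(-c2cc(-c3ccc(Cl)cc3)nc(-c3cccs3)c2)cc1`, gives 38.8% in this assay. Compound 3, `Oc1cccc(-c2cc(-c3ccc(Cl)cc3)nc(-c3cccnc3)c2)c1`, gives 2.8% in this assay.

Of the three measured compounds, compound 2 stands highest, and its steps to compound 1 and to compound 3 both lie beyond the scatter. How the core of compound 2 differs from that of compound 3 is not broken down here. Compound 1 and compound 3 share their core and differ in one place: 3-chlorophenyl in place of 4-chlorophenyl on an aromatic carbon. That change made a step of a number 24.8 percentage points higher from compound 3 to compound 1 (beyond the scatter), a modest rise.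

Compound 4, `Oc1ccc(-c2cc(-c3cccc(Cl)c3)nc(-c3cccs3)c2)cc1`, has not yet been measured. It relates to compound 2 as compound 1 relates to compound 3: 3-chlorophenyl in place of 4-chlorophenyl on an aromatic carbon. This is the same kind of change, though its surroundings differ. In compound 4 the changed position is meta to a 4-hydroxyphenyl group and meta to a thiophen-2-yl group, whereas in compound 1 it is meta to a 3-hydroxyphenyl group and meta to a pyridin-3-yl group. Among the compounds with values here, only one earlier instance exists, so the expectation rests on it alone. Because compound 3 to compound 1 gave a number 24.8 percentage points higher from compound 3 to compound 1 (beyond the scatter), a rise of similar direction, a number 16.2 percentage points higher from compound 2 to compound 4 (beyond the scatter), is expected for compound 4. Compound 4 is therefore estimated at 55%, within a range from 30% to 80%.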

Compound 4, a percentage reported as inhibition, at one concentration (the size of the read-out at that concentration, not a potency): 52.4%
For compound 4 the middle estimate is 2.6 percentage points above the measured one, within the range that was stated.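

In this assay, replacing 4-chlorophenyl with 3-chlorophenyl on the carbon next to the ring nitrogen gave a number 13.6 percentage points higher from compound 2 to compound 4 (beyond the scatter), so the change went in the same direction on the second core as on the first. The two rises cannot be told apart in size, so the change carried over from one core to the other in both direction and magnitude: the same change on two cores in this assay, a number 24.8 percentage points higher (beyond the scatter) from compound 3 to compound 1 and a number 13.6 percentage points higher (beyond the scatter) from compound 2 to compound 4, 11.2 percentage points apart, within the scatter of two such steps This is still only two instances, which does not establish a rule for the series, and the read-out, taken at one concentration, shows the size of the effect there and not a potency.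

The two cores differ both in the 3-hydroxyphenyl or 4-hydroxyphenyl group and in the pyridin-3-yl or thiophen-2-yl group, and the compounds shown do not separate these two differences, so it remains open whether either one alone would leave the step intact. As far as these compounds go, it is also open whether the rise belongs to the chlorine itself or to the position of the substituent, which a bromine, a methoxy group or an amine at the same place on the phenyl ring would begin to address.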